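Moving one oxygen in the side chain of compound 3

The source may report more compounds than this note shows. Statements on the series, on what has been measured and on what is new or still open speak of the compounds shown alone.

In an ADME assay on T29 cells (Homo sapiens) for cytotoxicity, read by sulforhodamine B assay, with a stated time of 3 days (a lower number here means a stronger inhibitor, a higher number a weaker inhibitor), compound 1 `O=CC1C(=O)N(Cc2ccc(Cl)cc2)c2cc(Cl)ccc21` gives 18600 nM, a true reading. Compound 2 `OCc1cn(Cc2ccc(Cl)cc2)c2ccccc12` reads > 31600 nM, which is a limit of the assay and not a number. Compound 3 `OCCc1cn(Cc2ccc(Cl)cc2)c2ccccc12` reads > 31600 nM, which is also a limit. Among the measured compounds shown here, compound 3 therefore has no exact place on the scale, and the only measured step that touches it is a step that the two limits leave unreadable from compound 2 to compound 3, so no size can be carried over from it.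

Compound 4 `COCc1cn(Cc2ccc(Cl)cc2)c2ccccc12` has the same atoms as compound 3, joined differently: methoxy in place of hydroxymethyl on a saturated chain carbon bound to an aromatic carbon. Nothing measured points to a large change from this swap. Compound 4 is expected to behave like compound 2 and compound 3 in this assay because of the limit of > 31600 nM in this assay, at which 2 of the 3 values shown sit, and it may well be reported only as a limit too. The expected change is an at least 1.0-fold lower number from compound 3 to compound 4 (0.02 log units; that floor lies within the scatter), which means no clear shift in either direction. For compound 4 the estimate is 30000 nM, with an expected range of 14000 nM to 50000 nM.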

Compound 4, half-maximal inhibitory concentration: > 31600 nM
Compound 4 ended at the assay's limit (the forecaster's own chance of this, stated with the estimate: 70%); middle value at least 1.0-fold (0.02 log units) from the limit.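

In this assay, among the compounds shown here, compound 2, compound 3 and compound 4 all stop at the limit of the assay, so no step among them can be read. From the compounds shown here alone, how strongly each of these three acts, and whether methoxy in place of hydroxymethyl changes that at all, remains open.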